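Aryl substitution on the styryl chain: a bromo entry

The source may report more compounds than this note shows. Statements on the series, on what has been measured and on what is new or still open speak of the compounds shown alone.

Compound 1 `CC1(C)CCC[C@]2(C)[C@@H](CC[C@@](C)(O)/C=C/c3ccccc3)[C@](C)(O)CC[C@@H]12` gives 3320 nM in a functional assay on HeLa cells (Homo sapiens) for cytotoxicity, read by MTT assay, with a stated time of 48 h (on this read-out lower numbers stand for stronger inhibition and higher numbers for weaker inhibition), the lowest of the three numbers, though within the scatter of compound 2 `COc1cccc(/C=C/[C@](C)(O)CC[C@@H]2[C@@]3(C)CCCC(C)(C)[C@@H]3CC[C@@]2(C)O)c1OC` at 3880 nM and of compound 3 `Cc1cccc(C)c1/C=C/[C@](C)(O)CC[C@@H]1[C@@]2(C)CCCC(C)(C)[C@@H]2CC[C@@]1(C)O` at 3460 nM. The steps of a 1.2-fold higher number from compound 1 to compound 2 (0.07 log units; within the scatter) and a 1.0-fold higher number from compound 1 to compound 3 (0.02 log units; within the scatter) show that groups placed on the phenyl ring left the number essentially where it was, and a 1.1-fold lower number from compound 2 to compound 3 (0.05 log units; within the scatter) says the same. Compound 4 `CC1(C)CCC[C@]2(C)[C@@H](CC[C@@](C)(O)/C=C/c3ccc(Br)cc3)[C@](C)(O)CC[C@@H]12` differs from compound 1 by bromo in place of hydrogen on an aromatic carbon. For the measured compounds named here, no measured step tests this exact change, but the three aryl variations bear on it, and all fell within the scatter, so in this assay no step beyond the scatter is expected. For compound 4 the estimate is 3400 nM, ranging from 1700 nM to 6800 nM, which is expected to amount to a 1.0-fold higher number from compound 1 to compound 4 (0.01 log units; within the scatter).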

Compound 4, half-maximal inhibitory concentration: 45900 nM
Estimate against measurement, compound 4: 14-fold (1.13 log units) below; the whole stated range lies below it.
By their numbers in this assay, from the lowest: compounds 1, 3 and 2 (each within the scatter of the next); then compound 4.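

Bromo on an aromatic carbon para to a large group is the first aryl change in this assay to go beyond the scatter (a 14-fold higher number from compound 1 to compound 4 (1.14 log units; beyond the scatter)). The 4-bromophenyl compound also stands apart from the other two aryl variants (a 13-fold higher number from compound 3 to compound 4 (1.12 log units; beyond the scatter)) and (a 12-fold higher number from compound 2 to compound 4 (1.07 log units; beyond the scatter)), so aryl substitution is not neutral across this series. Nothing available explains this large step.

From the compounds shown here alone, whether the step is specific to bromo or follows any group at this place remains open. Fluoro, methoxy or an amine on the same aromatic carbon would separate these two readings.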